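The compounds below may be only part of what the source reports. "The series", "measured", "known", "first", "only" and "open" are said of these compounds alone.

Compound 1 `Clc1cc(-c2ccn3c(CC4CC4)nnc3c2Cl)ccc1NC1CC1`: 6.1 nM
Compound 2 `Clc1cc(-c2ccn3c(CC4CC4)nnc3c2Cl)ccc1OC1CCOCC1`: 28.1 nM
Compound 3 `FC(F)(F)c1c(-c2ccc(OC3CCOCC3)c(Cl)c2)ccn2c(CC3CC3)nnc12`: 12.3 nM

In an assay on cells for binding affinity to metabotropic glutamate receptor 2 (Homo sapiens), read by scintillation proximity assay (a lower number here means tighter binding, a higher number weaker binding), compound 2 gives the highest number of the three measured compounds. The nearest is compound 3, reached by the step of a 2.3-fold lower number from compound 2 to compound 3 (0.36 log units; beyond the scatter); the furthest is compound 1, separated from it by the step of a 4.6-fold higher number from compound 1 to compound 2 (0.66 log units; beyond the scatter).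

Compound 4 `Clc1cc(-c2ccn3c(CC4CC4)nnc3c2Cl)ccc1NC1CCOCC1` differs from compound 2 in one place: (oxan-4-yl)amino in place of (oxan-4-yl)oxy on an aromatic carbon. Among the compounds with values here, only one measured step touches a change of this kind, a 4.6-fold higher number from compound 1 to compound 2 (0.66 log units; beyond the scatter), in which a cyclopropylamino group gave way to (oxan-4-yl)oxy, so that the ring and the linking atom changed together. That step cannot separate the two parts of its change, but the compound with the amino link is the tighter binder. The step of a 2.3-fold lower number from compound 2 to compound 3 (0.36 log units; beyond the scatter) concerns a different part of the molecule and says nothing about this exchange. A modest move toward tighter binding is therefore expected, a 2.3-fold lower number from compound 2 to compound 4 (0.37 log units; beyond the scatter), with real uncertainty because the comparison rests on a single mixed step, a 4.6-fold higher number from compound 1 to compound 2 (0.66 log units; beyond the scatter). Compound 4 is estimated at 12 nM, between 5 nM and 35 nM.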

Compound 4, dissociation constant: 19.5 nM
Compound 4: the middle estimate sits 1.6-fold (0.21 log units) below what was measured; the measured number falls inside the stated range.
By their numbers in this assay, from the lowest: compounds 1, 3, 4 and 2 (each within the scatter of the next, the first and the last beyond it).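

In this assay there is a 1.4-fold lower number from compound 2 to compound 4 (0.16 log units; within the scatter), so at this position, para to a large group, the oxygen link and the amino link cannot be told apart while the oxan-4-yl ring stays in place. With the amino link held constant, there is a 3.2-fold higher number from compound 1 to compound 4 (0.50 log units; beyond the scatter), which is close in size to the mixed step, a 4.6-fold higher number from compound 1 to compound 2 (0.66 log units; beyond the scatter), so the gap that step showed goes with the oxan-4-yl ring in place of cyclopropyl rather than with the linking atom. No measurement at hand gives a reason for either result.

The compounds shown leave open whether a cyclopropyl group on an oxygen link would bind as tightly as the cyclopropylamino group of compound 1. They also leave open how an ethyl chain or a piperidine ring on the nitrogen would compare with cyclopropyl and oxan-4-yl.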